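A few compounds are considered here, and "the series" means these few. Any claim that something is new, unique, unknown or untested is made for them only; others in the source may bear on it.

Measured compounds in an assay on cells for inhibition of cytochrome P450 11B2, mitochondrial (Homo sapiens), read by HTRF; a lower number here means a stronger inhibitor, a higher number a weaker inhibitor:
compound 1 `O=C1c2ccc(Cl)cc2CN1c1cccnc1`: 179 nM
compound 2 `CCC1c2cc(Cl)ccc2C(=O)N1c1cccnc1`: 121 nM
compound 3 `CC(=O)N[C@@H]1CCCc2c1cncc2N1Cc2cc(Cl)ccc2C1=O`: 44 nM

Compound 2 differs from compound 1 in one place: ethyl in place of hydrogen on a saturated ring carbon. In this assay this gave a 1.5-fold lower number from compound 1 to compound 2 (0.17 log units; within the scatter), so the two numbers are not separated. Compound 3 sits on a different core; the difference between the two cores is not broken down here. Its number in this assay is the lowest of the three, and its gaps to compound 2 and to compound 1 lie beyond the scatter.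

Compound 4 `CC[C@H]1c2cc(Cl)ccc2C(=O)N1c1cncc2c1CCC[C@H]2NC(C)=O` is not yet measured. It differs from compound 3 by ethyl in place of hydrogen on a saturated ring carbon. Among the measured compounds shown here, this is the same kind of change as the one from compound 1 to compound 2, though the surroundings are not identical: in compound 1 the neighbouring ring atom bears a pyridin-3-yl group, whereas in compound 3 it bears a large group.

In this assay the step is expected to be a 1.4-fold lower number from compound 3 to compound 4 (0.14 log units; within the scatter). This rests on compound 2 against compound 1, where the same change gave a 1.5-fold lower number from compound 1 to compound 2 (0.17 log units; within the scatter), a step within the scatter, applied to the measured value of compound 3, 44 nM. Accordingly compound 4 is estimated at 32 nM, with a likely range from 12 nM to 80 nM.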

Compound 4, half-maximal inhibitory concentration: 97 nM
Compound 4: middle estimate off by 3.0-fold (0.48 log units), on the low side; measured number outside the range, above it.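

In this assay, ethyl in place of hydrogen on a saturated ring carbon gives a 2.2-fold higher number from compound 3 to compound 4 (0.34 log units; beyond the scatter), so on the core of compound 3 the change brings a modest loss of inhibition. Among the compounds shown here, the step does not carry over unchanged from the core of compound 1, and the two steps are separated: the same change on two cores in this assay, a 1.5-fold lower number (0.17 log units; within the scatter) from compound 1 to compound 2 and a 2.2-fold higher number (0.34 log units; beyond the scatter) from compound 3 to compound 4, 3.3-fold (0.51 log units) apart, beyond the scatter of two such steps This shows that the effect of the ethyl group depends on the core, but it rests on only two matched pairs and does not show which difference between the cores is responsible, nor whether the ethyl group would have a consistent effect on any other core.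

The compounds shown leave open whether a smaller or longer chain, such as methyl or propyl, or a group such as hydroxymethyl at the same ring carbon would follow the step seen with ethyl on the core of compound 3. Also open, going by these compounds, is how the opposite configuration at the ethyl-bearing carbon would compare, since that carbon is drawn with a defined configuration in compound 4 and without one in compound 2.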